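A few compounds are considered here, and "the series" means these few. Any claim that something is new, unique, unknown or untested is made for them only; others in the source may bear on it.

Working notes on a series sharing one core, read in a functional assay on HL-60 cells (Homo sapiens) for inhibition, read by MTT assay, with a stated time of 48 h, tested at 10 uM; on this read-out lower numbers stand for less inhibition of growth and higher numbers for more inhibition of growth at the one concentration tested. Compound 1 `CCN(CC)Cc1c(O)c([C@H]2CCN(C)C[C@H]2O)c2oc(C)cc(=O)c2c1O` gives 47%, compound 2 `Cc1cc(=O)c2c(O)c(CN3CCC(N4CCCCC4)CC3)c(O)c([C@H]3CCN(C)C[C@H]3O)c2o1` gives 34%, and compound 3 `Cc1cc(=O)c2c(O)c(CN3CCCC3)c(O)c([C@H]3CCN(C)C[C@H]3O)c2o1` gives 38%. Compound 3 lies within the scatter of both others, so the three numbers do not separate. Compound 4 `Cc1cc(=O)c2c(O)c(CN3CCCC3CO)c(O)c([C@H]3CCN(C)C[C@H]3O)c2o1` carries hydroxymethyl in place of hydrogen on a saturated ring carbon of the pyrrolidine, next to the ring nitrogen: hydroxymethyl in place of hydrogen on a saturated ring carbon. Within the data shown here, the only measured step bearing on this is a number 9 percentage points lower from compound 1 to compound 3 (within the scatter), with pyrrolidin-1-yl in place of diethylamino. Among the measured compounds shown here, no measured step adds hydroxymethyl, so the guidance is indirect, and no step beyond the scatter is expected in this assay. The expected step is a number 1 percentage points lower from compound 3 to compound 4 (within the scatter). Compound 4 is estimated at 37%, with a range of 23% to 51%.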

Compound 4, percent growth inhibition at one concentration: 33%
Beside the measured number, compound 4's estimate is 4 percentage points above it; measured number inside the range.
By their numbers in this assay, from the lowest: compounds 4, 2, 3 and 1 (each within the scatter of the next, the first and the last beyond it).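

In this assay, hydroxymethyl in place of hydrogen on a saturated ring carbon, next to the ring nitrogen, gives a number 5 percentage points lower from compound 3 to compound 4 (within the scatter) and so does not separate from the unsubstituted pyrrolidine. Against the diethylamino group, 2-(hydroxymethyl)pyrrolidin-1-yl gives a number 14 percentage points lower from compound 1 to compound 4 (beyond the scatter) as a step beyond the scatter, which pyrrolidin-1-yl alone did not give. Nothing measured bears on the reason for either step. Still open, on these data alone, is whether an amine, a carboxylic acid or a longer hydroxyalkyl chain at this ring carbon would move the read-out beyond the scatter from compound 3.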